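The compounds below may be only part of what the source reports. "The series", "measured", "known", "first", "only" and "open" are said of these compounds alone.

Compound 1 `C[C@H](O)CONC(=O)c1oc2c(F)cncc2c1Nc1ccc(I)cc1F`: 175 nM
Compound 2 `O=C(NOCCO)c1ccc2[nH]ncc2c1Nc1ccc(I)cc1F`: 16 nM

In a functional assay on HCT-116 cells (Homo sapiens) for antiproliferative activity, read by CellTiter-Glo, with a stated time of 72 h (on this read-out lower numbers stand for an effect already at smaller amounts and higher numbers for an effect only at larger amounts of compound), compound 2 has the lower of the two numbers, 16 nM, and compound 1 stands at 175 nM, a gap beyond the usual scatter. Compound 3 `O=C(NOCCO)c1ccc2[nH]ncc2c1Nc1ccc(Br)cc1F` differs from compound 2 in one place: bromo in place of iodo on an aromatic carbon. It carries bromo in place of iodo on an aromatic carbon. For the measured compounds named here, no measured pair shows this change, so only a modest move towards a higher number in this assay is expected, perhaps none beyond the scatter. The estimated step is a 1.9-fold higher number from compound 2 to compound 3 (0.27 log units; within the scatter). Compound 3 is expected at 30 nM, within an estimated range of 12 nM to 75 nM.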

Compound 3, half-maximal effective concentration: 193 nM
Compound 3: the middle estimate sits 6.4-fold (0.81 log units) below what was measured, outside the stated range (above it).
By their numbers in this assay, from the lowest: compound 2; then compounds 1 and 3 (each within the scatter of the next).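

In this assay, the halogen on the aromatic carbon para to a large group proves decisive: bromo in place of iodo gives a 12-fold higher number from compound 2 to compound 3 (1.08 log units; beyond the scatter), although one heavy atom simply replaces another and no hydrogen-bond donor or acceptor is gained or lost. Compounds 1 and 2 differ in more than one place, so they could not isolate this position. Nothing measured here accounts for the size of this step. Open, going by these compounds, is how chloro, methyl or ethynyl would fare at this position, and whether iodo holds the same advantage on the core of compound 1.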